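A few compounds are considered here, and "the series" means these few. Any claim that something is new, unique, unknown or untested is made for them only; others in the source may bear on it.

Compound 3 `Cc1cccc(-n2cc(-c3cccc(NS(=O)(=O)c4c[nH]c(=O)[nH]c4=O)c3)nn2)c1` is one of three compounds with numbers in a functional assay on OVCAR-3 cells (Homo sapiens) for antiproliferative activity, read by MTT assay, with a stated time of 24 h; on this read-out higher numbers stand for weaker inhibition and lower numbers for stronger inhibition. In this assay compound 3 gives 4080 nM. Its nearest neighbour is compound 1 `Cc1cccc(-n2cc(-c3ccccc3NS(=O)(=O)c3c[nH]c(=O)[nH]c3=O)nn2)c1`, which in this assay gives 3150 nM, a gap that lies within the scatter, so no order between compound 1 and compound 3 can be claimed. Compound 2 `O=c1[nH]cc(S(=O)(=O)Nc2cccc(-c3cn(-c4ccccc4)nn3)c2)c(=O)[nH]1` is different: in this assay compound 2 reaches only the limit > 20000 nM, and this is a limit of the assay, not a number (the limit of > 20000 nM in this assay, at which 1 of the 3 values shown sits). Within the data shown here, the single step that can be measured runs from compound 2 to compound 3 and amounts to an at least 4.9-fold lower number from compound 2 to compound 3 (0.69 log units; beyond the scatter), so the methyl on the phenyl ring carries a modest but real share of the activity.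

Compound 4 `O=c1[nH]cc(S(=O)(=O)Nc2cccc(-c3cn(-c4ccccc4F)nn3)c2)c(=O)[nH]1` differs from compound 3 by the change (2-fluorophenyl in place of 3-methylphenyl on an aromatic nitrogen). The measured step bears on it only in part: the methyl that mattered in the step from compound 2 to compound 3 is gone, while a fluorine enters on the ring at a different position, for which no comparison exists. He therefore expects a weakening, a step of about a 2.9-fold higher number from compound 3 to compound 4 (0.47 log units; beyond the scatter), with a real chance that only a limit is reported. His estimate for compound 4 in this assay is 12000 nM, within a range of 4000 nM to 40000 nM.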

Compound 4, half-maximal inhibitory concentration: 12500 nM
Beside the measured number, compound 4's estimate is 1.0-fold (0.02 log units) below it, and the stated range covers the measured number.
By their numbers in this assay, from the lowest: compounds 1 and 3 (each within the scatter of the next); then compound 4. At a limit, above all of these: compound 2.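

In this assay, the exchange of 3-methylphenyl for 2-fluorophenyl on the aromatic nitrogen of the five-membered ring gives a 3.1-fold higher number from compound 3 to compound 4 (0.49 log units; beyond the scatter), a modest loss that shows that this position responds to a change of the whole aryl group and not only to the addition of a methyl. Adding a fluorine to the phenyl ring gives an at least 1.6-fold lower number from compound 2 to compound 4 (0.20 log units; that floor lies within the scatter), so compound 4 yields a measured number, but no gain beyond the scatter can be claimed for the fluorine. Compound 2 stands at a limit of the assay and not at a number: the limit of > 20000 nM in this assay, at which 1 of the 4 values shown sits.

Compounds 3 and 4 change both the substituent and its place on the phenyl ring, and the compounds shown do not separate these two changes. As far as these compounds go, it also remains open how this position in this assay would respond to an amine or a carboxylic acid on the phenyl ring, or to a longer chain in place of the phenyl ring.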